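The source may report more compounds than this note shows. Statements on the series, on what has been measured and on what is new or still open speak of the compounds shown alone.

In an assay on Sf21 cells for inhibition of high affinity nerve growth factor receptor (Homo sapiens), read by HTRF, with a stated time of 30 min, in the presence of a further agent that is not named here (on this read-out higher numbers stand for weaker inhibition and lower numbers for stronger inhibition), compound 2 `CC1(C)c2[nH]nc(NC(=O)c3ccc(F)cc3)c2CN1Cc1cccc(F)c1F` gives 210 nM, the second highest of three numbers; compound 1 `CC1(C)c2[nH]nc(NC(=O)c3ccccc3)c2CN1Cc1cccc(F)c1F` gives 200 nM, and compound 3 `CC1(C)c2[nH]nc(NC(=O)c3ccc(F)cc3)c2CN1Cc1cc(F)cc(F)c1` gives 350 nM. Compound 4 `CC1(C)c2[nH]nc(NC(=O)c3ccc(Br)cc3)c2CN1Cc1cccc(F)c1F` differs from compound 2 by bromo in place of fluoro on an aromatic carbon. The step that bears most on this is a 1.1-fold higher number from compound 1 to compound 2 (0.02 log units; within the scatter), where fluoro entered that same position; a 1.7-fold higher number from compound 2 to compound 3 (0.22 log units; within the scatter) shows a change elsewhere, also within the scatter. Since the earlier change at this aromatic carbon left the number where it was, compound 4 is expected to stay within the scatter of compound 2, with a step of a 1.1-fold lower number from compound 2 to compound 4 (0.02 log units; within the scatter). The estimate for compound 4 is therefore 200 nM, likely between 100 nM and 400 nM.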

Compound 4, half-maximal inhibitory concentration: 950 nM
Beside the measured number, compound 4's estimate is 4.8-fold (0.68 log units) below it, outside the stated range (above it).
By their numbers in this assay, from the lowest: compounds 1, 2 and 3 (each within the scatter of the next); then compound 4.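

This aromatic carbon is not indifferent to what it carries: hydrogen and fluoro cannot be told apart here, but bromo weakens inhibition beyond the scatter, against fluoro (a 4.5-fold higher number from compound 2 to compound 4 (0.66 log units; beyond the scatter)) and against hydrogen (a 4.8-fold higher number from compound 1 to compound 4 (0.68 log units; beyond the scatter)). So the lack of change on adding fluoro did not extend to every group at this position. Nothing available explains why bromo behaves differently.

On these data alone, whether chloro would fall with fluoro or with bromo remains open. Also open, as far as these compounds go, is whether a methyl or methoxy group at this carbon would weaken inhibition as bromo does.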